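Swapping a phenoxy for a dimethylamino on the shared core

A few compounds are considered here, and "the series" means these few. Any claim that something is new, unique, unknown or untested is made for them only; others in the source may bear on it.

Measured so far:
compound 1, `COc1cc(C)cc(-c2c(-c3ccnc(-c4ccc(C(C)=O)cc4)c3)cnn2CC#N)c1`, 2610 nM
compound 2, `Cc1cc(O)cc(-c2nn(CC#N)cc2-c2ccnc(-c3ccc(Oc4ccccc4)cc3)c2)c1`, 1880 nM

Both values come from a functional assay on OVCAR-3 cells (Homo sapiens) for inhibition, read by sulforhodamine B assay, with a stated time of 48 h; on this read-out lower numbers stand for stronger inhibition of growth and higher numbers for weaker inhibition of growth. Compound 2 shows the lower of the two numbers, but the number for compound 1 lies within the usual scatter of such measurements, so the two compounds cannot be told apart on this evidence. Within the data shown here, no pair of measured compounds differs in only one place, so there is no measured step to lean on.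

Compound 3, `Cc1cc(O)cc(-c2nn(CC#N)cc2-c2ccnc(-c3ccc(N(C)C)cc3)c2)c1`, has not been measured. It is built from compound 2 by one change: dimethylamino in place of phenoxy on an aromatic carbon. In this assay, among the measured compounds shown here, no step of a comparable kind has been measured, so the direction of the effect is unknown; the expectation is a change no larger than the scatter, with the risk of weaker inhibition judged somewhat greater than that of stronger inhibition. The step from compound 2 to compound 3 is therefore expected to be small, a 1.3-fold higher number from compound 2 to compound 3 (0.12 log units; within the scatter). Compound 3 is estimated at 2500 nM, with a range from 900 nM to 7000 nM.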

Compound 3, concentration for 50% growth inhibition: 1910 nM
For compound 3 the middle estimate is 1.3-fold (0.12 log units) above the measured one; the measured number falls inside the stated range.
By their numbers in this assay, from the lowest: compounds 2, 3 and 1 (each within the scatter of the next).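

In this assay, among these compounds, the single step at this position runs a 1.0-fold higher number from compound 2 to compound 3 (0.01 log units; within the scatter) and places dimethylamino in place of phenoxy on an aromatic carbon, para to a large group. The two groups are far from alike in build: phenoxy has 7 heavy atoms and a six-membered aromatic ring of carbon only, while dimethylamino has 3 heavy atoms and no ring, yet this read-out cannot tell compound 2 and compound 3 apart, so for this one pair, removing that outer ring leaves no visible mark on growth inhibition. No measured property of these compounds bears on this result, and the reason for the match remains unknown.

On these data alone, whether a carboxylic acid, a primary amine or a longer chain on the same aromatic carbon would also read like phenoxy and dimethylamino remains open. Also open, as far as these compounds go, is whether the same swap would give so small a step on a different core, such as that of compound 1, as one pair cannot show whether the result holds beyond compound 2 and compound 3.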